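A few compounds are considered here, and "the series" means these few. Any claim that something is new, unique, unknown or untested is made for them only; others in the source may bear on it.

Working notes on the series.

Compound 1 `CCC(C)(C)Cc1c[nH]c(CCc2ccc(-n3ccnn3)cc2)n1` and compound 2 `CCC(C)(C)Cc1c[nH]c(CCc2ccc(-c3ccc(F)cn3)cc2)n1` share one core and differ only in the aromatic group at the far end of the ethylene-linked benzene. Among the measured compounds shown here, in a functional assay on HEK293 cells for agonist activity at Bombesin receptor subtype-3 (Homo sapiens), read by luminescence and calcium flux, with a stated time of 10 min (a higher number here means that more compound is needed for the effect, a lower number that less compound is needed), compound 1 gives 641 nM, while compound 2 gives 66 nM, the lower of the two numbers on record; the step of a 9.7-fold lower number from compound 1 to compound 2 (0.99 log units; beyond the scatter) is the only measured step in the set. For the measured compounds named here, compound 2 therefore stands at the low end of what has been measured, with compound 1 as its sole neighbour.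

Compound 3 `CCC(C)(C)Cc1c[nH]c(CCc2ccc(-c3cccc(N)n3)cc2)n1` has not yet been measured. It differs from compound 2 in one place: 6-aminopyridin-2-yl in place of 5-fluoropyridin-2-yl on an aromatic carbon. Going by the values given here, no measured step exchanges one pyridinyl group for another; the one measured step, a 9.7-fold lower number from compound 1 to compound 2 (0.99 log units; beyond the scatter), shows only how far changing the aromatic group at this position can move the number. Given that, a modest shift in either direction is the honest expectation, with a slight lean towards a higher number, estimated as a 2.0-fold higher number from compound 2 to compound 3 (0.29 log units; within the scatter). For compound 3 the expected value in this assay is 130 nM, with a range from 35 nM to 500 nM.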

Compound 3, half-maximal effective concentration: 37 nM
For compound 3 the middle estimate is 3.5-fold (0.55 log units) above the measured one, within the range that was stated.
By their numbers in this assay, from the lowest: compounds 3 and 2 (each within the scatter of the next); then compound 1.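

In this assay, 6-aminopyridin-2-yl in place of 5-fluoropyridin-2-yl gives a 1.8-fold lower number from compound 2 to compound 3 (0.25 log units; within the scatter), so at this position one pyridinyl group can replace another, with a hydrogen-bond donor entering and the fluorine leaving, without a change that can be told from the scatter. Against the 1H-1,2,3-triazol-1-yl group, the new group gives a 17-fold lower number from compound 1 to compound 3 (1.24 log units; beyond the scatter), which means that among the three compounds shown, both pyridinyl groups stand clear of the triazolyl group, and the earlier difference no longer rests on a single pyridinyl example. Nothing on record accounts for the gap between the triazolyl and pyridinyl compounds, or for the closeness of the two pyridinyl compounds.

The compounds shown leave open what the amine contributes, since the amino and fluoro groups differ in both identity and ring position; an unsubstituted pyridin-2-yl group or a 6-methylpyridin-2-yl group would help to separate the amine from the ring itself. They also leave open whether the 6-aminopyridin-2-yl group would give a similar result with a cyclohexyl group at the other end of the shared core.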